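The source may report more compounds than this note shows. Statements on the series, on what has been measured and on what is new or still open speak of the compounds shown alone.

Compound 1 `COc1ccc(/C=C\c2cc(OC)c(OC)c(OC)c2)cc1OCc1ccc(C=O)cc1`: in a functional assay on B16-F10 cells (Mus musculus) for antiproliferative activity, read by CCK-8 assay, with a stated time of 48 h (a lower number here means a stronger inhibitor, a higher number a weaker inhibitor), compound 1 gives 4200 nM.
Compound 2 `COc1ccc(/C=C\c2cc(OC)c(OC)c(OC)c2)cc1OCc1ccc(CN2CCCC[C@@H]2C(=O)O)cc1`: in this assay compound 2 gives only a limit, > 10000 nM.
Compound 3 `COc1ccc(/C=C\c2cc(OC)c(OC)c(OC)c2)cc1OCc1ccc(CNCCO)cc1`: in this assay compound 3 gives 6600 nM.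

Among the two numbers shown, compound 3 carries the higher one, with compound 1 nearest: a 1.6-fold higher number from compound 1 to compound 3 (0.20 log units; within the scatter). Compound 4 `COc1ccc(/C=C\c2cc(OC)c(OC)c(OC)c2)cc1OCc1ccc(CN2CC[C@@H](O)C2)cc1` is the next step from compound 3, with 3-hydroxypyrrolidin-1-yl in place of (2-hydroxyethyl)amino on a saturated chain carbon bound to an aromatic carbon. Among the compounds with values here, the one measured step that bears on this is an at least 1.5-fold lower number from compound 2 to compound 3 (0.18 log units; that floor lies within the scatter), where a ring-bound amine carrying a carboxylic acid is swapped for the open (2-hydroxyethyl)amino; compound 2 itself sits at a limit (the limit of > 10000 nM in this assay, at which 1 of the 3 values shown sits), so the size of that step is only a floor. Compound 4 again closes the amine into a ring, yet keeps a hydroxyl rather than an acid, so in this assay the expected step of a 1.1-fold higher number from compound 3 to compound 4 (0.06 log units; within the scatter) is small or none beyond the scatter. Compound 4 is therefore estimated at 7500 nM, between 3500 nM and 16000 nM.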

Compound 4, half-maximal inhibitory concentration: > 10000 nM
Compound 4 ended at the assay's limit; the forecaster's own chance of this, stated with the estimate: 30%; at least 1.3-fold (0.12 log units) between middle value and limit.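

Closing the open (2-hydroxyethyl)amino into 3-hydroxypyrrolidin-1-yl at this saturated chain carbon gives an at least 1.5-fold higher number from compound 3 to compound 4 (0.18 log units; that floor lies within the scatter) in this assay, so the ring cannot yet be ranked against the open chain. Set against formyl, (3-hydroxypyrrolidin-1-yl)methyl gives an at least 2.3-fold higher number from compound 1 to compound 4 (0.37 log units; beyond the scatter), so a step of this kind also occurs with a ring amine that has no carboxylic acid. The step between compound 2 and compound 4 cannot be read, because both stand at a limit: the limit of > 10000 nM in this assay, at which 2 of the 4 values shown sit.

Open, from the compounds shown here alone, is whether morpholine, plain pyrrolidine or 4-hydroxypiperidine would give a readable number in this assay. Open too, going by these compounds, is how the mirror-image form of the 3-hydroxypyrrolidin-1-yl group would behave.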